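The compounds below may be only part of what the source reports. "The series", "measured", "known", "first", "only" and "open" are said of these compounds alone.

Measured so far in a physicochemical assay, with a stated time of 30 min; on this read-out lower numbers stand for stronger inhibition and higher numbers for weaker inhibition:
- compound 1 `COc1cc2c(cc1OC)C(=O)C(C(=O)Nc1ccc(Cl)cc1)C2` (56.8 ug/mL)
- compound 2 `COc1cc2c(cc1OC)C(=O)C(C(=O)Nc1cccc(Cl)c1)C2` (76.3 ug/mL)

Among the measured compounds shown here, compound 2 (76.3 ug/mL) stands within the scatter of the only other number. Next comes compound 3 `COc1cc2c(cc1OC)C(=O)C(C(=O)Nc1ccccc1C)C2`, with 2-methylphenyl in place of 3-chlorophenyl on an amide-type nitrogen. For the measured compounds named here, the one measured step that bears on this, a 1.3-fold higher number from compound 1 to compound 2 (0.13 log units; within the scatter), also changes only the group on that nitrogen. Going by the values given here, no measured step exchanges chlorophenyl for methylphenyl, so the guide is thin. No step beyond the scatter is expected in this assay. The expected step is a 1.1-fold lower number from compound 2 to compound 3 (0.04 log units; within the scatter). For compound 3 the estimated value is 70 ug/mL (expected range 30 ug/mL to 160 ug/mL).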

Compound 3, half-maximal inhibitory concentration: 43.7 ug/mL
Compound 3: the middle estimate sits 1.6-fold (0.20 log units) above what was measured, and the stated range covers the measured number.
By their numbers in this assay, from the lowest: compounds 3, 1 and 2 (each within the scatter of the next).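

On the amide-type nitrogen, 2-methylphenyl is tolerated in place of either chlorophenyl group in this assay: a 1.7-fold lower number from compound 2 to compound 3 (0.24 log units; within the scatter) and a 1.3-fold lower number from compound 1 to compound 3 (0.11 log units; within the scatter) both lie within the scatter. Chlorine is therefore not required on this phenyl group for a number in this range, although each step changes both the substituent and its place on the ring. Nothing available bears on a cause for these steps.

From the compounds shown here alone, it remains open whether a carboxylic acid or an amine on the phenyl group, or a longer chain on that nitrogen, would give a step beyond the scatter.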